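One methyl added to compound 2

This account rests on a few compounds, and the source may have more. Where it says the series, first, only, none or still open, it means among the compounds named here.

Compound 1 `S=C=NCCCN=C=S`: 1840 nM
Compound 2 `S=C=Nc1cccc(N=C=S)c1`: 46400 nM

In a functional assay on LoVo cells (Homo sapiens) for antiproliferative activity, read by sulforhodamine B assay, with a stated time of 72 h (on this read-out lower numbers stand for stronger inhibition and higher numbers for weaker inhibition), compound 2 gives 46400 nM, the higher of the two numbers and so the weaker inhibition. The gap between compound 2 and compound 1 lies beyond the usual scatter of repeated measurements.

Compound 3 `Cc1ccc(N=C=S)cc1N=C=S` is compound 2 with one change: methyl in place of hydrogen on an aromatic carbon. For the measured compounds named here, no two measured compounds differ in one place only, so the data give no direct measure of such a change. The expectation therefore starts from compound 2 at 46400 nM and rests on the small size of the change alone. The expected 1.2-fold lower number from compound 2 to compound 3 (0.06 log units; within the scatter) stays within the scatter, with no clear direction. For compound 3 the estimated value is 40000 nM, with an expected range of 15000 nM to 90000 nM.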

Compound 3, half-maximal inhibitory concentration: 35200 nM
Beside the measured number, compound 3's estimate is 1.1-fold (0.06 log units) above it; measured number inside the range.
By their numbers in this assay, from the lowest: compound 1; then compounds 3 and 2 (each within the scatter of the next).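

In this assay, methyl in place of hydrogen on this aromatic carbon, ortho to one group of 3 heavy atoms and para to another, gives a 1.3-fold lower number from compound 2 to compound 3 (0.12 log units; within the scatter), so compound 2 and compound 3 cannot be told apart on this read-out. For the compounds shown here, this is the first comparison here of two compounds that differ in one place only, and it shows that this single added carbon at this position leaves the number inside the usual scatter. Nothing measured here speaks to the reason for this result.

From the compounds shown here alone, whether an ethyl group, an amine or a carboxylic acid on this same carbon, or a methyl on another carbon of the ring, would also stay within the scatter remains open. Compound 1 differs from compound 2 in more than one place, so these compounds do not show which structural difference separates their numbers.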